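Ring size of the basic amine tail: compound 1 to compound 4

This account rests on a few compounds, and the source may have more. Where it says the series, first, only, none or still open, it means among the compounds named here.

Measured in a functional assay on HT-29 cells (Homo sapiens) for antiproliferative activity, read by MTT assay, with a stated time of 72 h; a higher number here means a weaker inhibitor, a lower number a stronger inhibitor:
compound 1 `COc1cc2c(Oc3ccc(NC(=O)C4(c5nnc(-c6ccc(F)cc6)o5)CC4)cc3F)ccnc2cc1OCCCN1CCCC1`: 779 nM
compound 2 `COc1cc2c(Oc3ccc(NC(=O)c4nnc(-c5ccc(F)cc5)o4)cc3)ccnc2cc1OCCCN1CCC(C)CC1`: 7890 nM
compound 3 `COc1cc2c(Oc3ccc(NC(=O)c4ncc(-c5ccc(F)cc5)o4)cc3)ccnc2cc1OCCCN1CCC(C)CC1`: 1890 nM

Compound 1 stands lowest in this assay, beyond the scatter against both compound 3 and compound 2, so it is the strongest inhibitor of the three. Among the measured compounds shown here, the only single-point step measured is a 4.2-fold lower number from compound 2 to compound 3 (0.62 log units; beyond the scatter), which concerns the heteroaryl amide and not the amine tail. Compound 4 `COc1cc2c(Oc3ccc(NC(=O)C4(c5nnc(-c6ccc(F)cc6)o5)CC4)cc3F)ccnc2cc1OCCCN1CCCCC1` differs from compound 1 by piperidin-1-yl in place of pyrrolidin-1-yl on a saturated chain carbon, three bonds along the chain from an oxygen on an aromatic ring. For the measured compounds named here, no measured pair isolates this change; compound 2 and compound 3 carry a methyl-bearing piperidine but also differ elsewhere, so their values give no clean guide. The expectation is therefore a step of a 1.0-fold higher number from compound 1 to compound 4 (0.01 log units; within the scatter) that stays within the scatter. Compound 4 is estimated at 800 nM, with a range from 400 nM to 1600 nM.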

Compound 4, half-maximal inhibitory concentration: 1030 nM
Compound 4: the middle estimate sits 1.3-fold (0.11 log units) below what was measured; the range from low to high includes it.
By their numbers in this assay, from the lowest: compounds 1, 4 and 3 (each within the scatter of the next, the first and the last beyond it); then compound 2.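

In this assay, among the compounds shown here, the step is a 1.3-fold higher number from compound 1 to compound 4 (0.12 log units; within the scatter), the first measured pair that isolates the amine tail. At the end of the 3-carbon-linked tail, as 3-(pyrrolidin-1-yl)propyl or 3-(piperidin-1-yl)propyl, the five-membered and six-membered rings cannot be told apart in this series. Nothing on hand accounts for this result.

Open, on these data alone, is whether a morpholin-4-yl group, an open-chain dimethylamino group or a shorter chain at this position would read the same. Also open, as far as these compounds go, is whether the ring swap reads the same on the amide of compound 3.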